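Amide nitrogen substituent change from compound 3 to compound 4

This account rests on a few compounds, and the source may have more. Where it says the series, first, only, none or still open, it means among the compounds named here.

In a functional assay on Caco-2 cells (Homo sapiens) for antiproliferative activity, read by MTT assay, with a stated time of 48 h (on this read-out lower numbers stand for stronger inhibition and higher numbers for weaker inhibition), compound 3 `CCOC(=O)C(CC(=O)OC)NC(=O)c1ccc(C(CC)(CC)c2ccc(OCCC(O)(CC)CC)c(C)c2)n1CC` gives 3020 nM and compound 1 `CCN(CC)CCNC(=O)c1ccc(C(CC)(CC)c2ccc(OCCC(O)(CC)CC)c(C)c2)n1CC` gives 1630 nM on the same shared core. The step of a 1.9-fold higher number from compound 1 to compound 3 (0.27 log units; within the scatter) puts these two together. Compound 2 `CCC(C)C(NC(=O)c1ccc(C(CC)(CC)c2ccc(OCCC(O)(CC)CC)c(C)c2)n1CC)C(=O)OC` gives > 50000 nM as a limit of this assay and not a number. Its steps are large: an at least 30-fold higher number from compound 1 to compound 2 (1.48 log units; beyond the scatter) and an at least 16-fold lower number from compound 2 to compound 3 (1.21 log units; beyond the scatter) on the same nitrogen.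

Compound 4 `CCC(C)C(CO)NC(=O)c1ccc(C(CC)(CC)c2ccc(OCCC(O)(CC)CC)c(C)c2)n1CC` differs from compound 3 by a group of 7 heavy atoms (6 carbon, 1 oxygen; no ring) in place of a group of 11 heavy atoms (7 carbon, 4 oxygen; no ring), on an amide-type nitrogen with 1-(hydroxymethyl)-2-methylbutyl entering on the amide-type nitrogen. Compound 2 also carries a 2-methylbutyl chain there, so an at least 16-fold lower number from compound 2 to compound 3 (1.21 log units; beyond the scatter) bears most, and a higher number is expected, though short of that size. The expected move is a 3.0-fold higher number from compound 3 to compound 4 (0.47 log units; beyond the scatter) in this assay overall. Estimated for compound 4: 9000 nM with 2500 nM to 40000 nM as the expected range.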

Compound 4, half-maximal inhibitory concentration: > 50000 nM
Compound 4: no number, only a limit; the forecaster's own chance of this, stated with the estimate: 20%; middle value at least 5.5-fold (0.74 log units) away from the limit.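

Replacing the group of compound 3 with 1-(hydroxymethyl)-2-methylbutyl on the amide-type nitrogen gives a large step, an at least 16-fold higher number from compound 3 to compound 4 (1.21 log units; beyond the scatter), and replacing the 2-(diethylamino)ethyl group of compound 1 gives another, an at least 30-fold higher number from compound 1 to compound 4 (1.48 log units; beyond the scatter). With hydroxymethyl in place of methoxycarbonyl, the 2-methylbutyl chain still gives no number, and the step between compound 2 and compound 4 cannot be read, as both values are limits: the limit of > 50000 nM in this assay, at which 2 of the 4 values shown sit.

Going by these compounds, it remains open whether the 2-methylbutyl chain alone sets this limit. Also open, on these data alone, is whether a carboxylic acid or an amine in place of hydroxymethyl on that chain would give a number.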